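The source may hold more compounds than are shown below. What is called first, only, known or untested is meant among the compounds shown, and "the series" means these compounds.

Working notes on the series. Among the compounds with values here, in an assay on isolated protein for binding affinity to melatonin receptor type 1A (Homo sapiens) (on this read-out higher numbers stand for weaker inhibition and lower numbers for stronger inhibition), compound 2 `COc1cccc(N(C)c2ccc(NC(C)=O)cc2)c1` gives 0.05 nM and compound 3 `CCC(=O)Nc1ccc(N(C)c2cccc(OC)c2)cc1` gives 1 nM; compound 3 thus holds the highest of the two numbers, with the step of a 20-fold higher number from compound 2 to compound 3 (1.30 log units; beyond the scatter) the only measured step. For compound 1 `COc1cccc(Nc2ccc(NC(=O)C(C)C)cc2)c1` this assay reports only a limit, > 500 nM. Compound 4 `COc1cccc(N(C)c2ccc(NC(=O)C(C)C)cc2)c1` is not yet measured; against compound 3 the change is methyl in place of hydrogen on a saturated chain carbon bound to a carbonyl carbon and a saturated chain carbon. Within the data shown here, the one measured step, from compound 2 to compound 3, adds a methyl at this same place and weakens binding by a large margin, so a further methyl is expected to push the number of compound 4 higher again in this assay, by about a 20-fold higher number from compound 3 to compound 4 (1.30 log units; beyond the scatter). Compound 4 is therefore expected near 20 nM, within 3 nM to 150 nM.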

Compound 4, inhibition constant: 106 nM
The estimate for compound 4 lay 5.3-fold (0.72 log units) below the measured number; measured number inside the range.
By their numbers in this assay, from the lowest: compound 2; then compound 3; then compound 4. At a limit, above all of these: compound 1.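

The second methyl at this place also weakens binding, the step of a 110-fold higher number from compound 3 to compound 4 (2.03 log units; beyond the scatter), so the loss does not stop at ethyl but continues to isopropyl. Taken whole, isopropyl in place of methyl on a carbonyl carbon gives the step of a 2100-fold higher number from compound 2 to compound 4 (3.33 log units; beyond the scatter), the widest span in the series. Compound 1 holds a limit, not a number, so the step of an at least 4.7-fold lower number from compound 1 to compound 4 (0.67 log units; beyond the scatter) only bounds the effect of methyl in place of hydrogen on a nitrogen on an aromatic ring: the limit of > 500 nM in this assay, at which 1 of the 4 values shown sits.

Open, from the compounds shown here alone, is whether the rise follows branching or the added carbon alone. A straight propyl chain on the carbonyl carbon would separate the two.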